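A few compounds are considered here, and "the series" means these few. Any claim that something is new, unique, unknown or untested is made for them only; others in the source may bear on it.

Within the data shown here, in a functional assay on K562 cells (Homo sapiens) for antiproliferative activity, read by MTT assay, with a stated time of 48 h (on this read-out lower numbers stand for stronger inhibition and higher numbers for weaker inhibition), only two compounds have numbers so far. Compound 1 (`Cn1cc(C2=C(c3nn(CCCN4CCCCC4)c4ncccc34)C(=O)N(c3ccccc3)C2=O)c2ccccc21`) gives 3790 nM and compound 2 (`Cn1cc(C2=C(c3nn(CCCn4cccc4)c4ncccc34)C(=O)NC2=O)c2ccccc21`) gives 21600 nM (the higher of the two numbers, and the gap between them lies beyond the usual scatter of repeat measurements). Compound 3 (`CN(C)CCCn1nc(C2=C(c3cn(C)c4ccccc34)C(=O)NC2=O)c2cccnc21`) has not yet been measured. It differs from compound 2 in one place (dimethylamino in place of 1H-pyrrol-1-yl on a saturated chain carbon, three bonds along the chain from an aromatic nitrogen): dimethylamino stands in place of 1H-pyrrol-1-yl on a saturated chain carbon, three bonds along the chain from an aromatic nitrogen. Among the measured compounds shown here, no measured pair shows this change on its own, so any expectation is loose. A moderate step toward a lower number, beyond the scatter, seems most likely. The step expected here is a 3.1-fold lower number from compound 2 to compound 3 (0.49 log units; beyond the scatter) and it remains an estimate. Compound 3 is expected at 7000 nM (estimated range 2000 nM to 25000 nM).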

Compound 3, half-maximal inhibitory concentration: 50400 nM
Compound 3: middle estimate off by 7.2-fold (0.86 log units), on the low side; the whole stated range lies below it.
By their numbers in this assay, from the lowest: compound 1; then compound 2; then compound 3.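

In this assay, the change of dimethylamino in place of 1H-pyrrol-1-yl on a saturated chain carbon, three bonds along the chain from an aromatic nitrogen, gives a 2.3-fold higher number from compound 2 to compound 3 (0.37 log units; beyond the scatter) and so moves toward weaker inhibition. Among these compounds, this is the first direct reading at this position, and it shows that replacing the five-membered aromatic ring with an open group of fewer heavy atoms does not lower the number in this pair. No measurement shown here bears on the reason for this step.

The compounds shown leave open where a primary amine on the same chain, or dimethylamino on a longer chain, would fall. They also leave open whether this change would give a similar step in a compound carrying the phenyl group of compound 1.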